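From chloro to ethoxycarbonyl in a level series

The source may hold more compounds than are shown below. What is called first, only, known or untested is meant among the compounds shown, and "the series" means these compounds.

Of the compounds shown here, three sharing one core have been measured in an ADME assay on MT4 cells (Homo sapiens) for cytotoxicity, read by MTT assay; on this read-out higher numbers stand for lower toxicity in this test and lower numbers for higher toxicity in this test. Compound 1 `O=C(CSc1nncnc1-c1cccc2ccccc12)Nc1ccccc1[N+](=O)[O-]` gives 142000 nM, compound 2 `O=C(CSc1nncnc1-c1cccc2ccccc12)Nc1ccc(Cl)cc1Cl` gives 254000 nM, and compound 3 `Cc1ccccc1NC(=O)CSc1nncnc1-c1cccc2ccccc12` gives 158000 nM. These values lie within the usual scatter of repeat measurements, so compound 2 cannot be told apart from the other two.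

The unmeasured compound 4 `CCOC(=O)c1ccc(NC(=O)CSc2nncnc2-c2cccc3ccccc23)c(Cl)c1` carries ethoxycarbonyl in place of chloro on an aromatic carbon of compound 2: ethoxycarbonyl in place of chloro on an aromatic carbon. That carbon is para to a large group and meta to a chloro group.

The measured steps all alter the group on the amide-type nitrogen. Two of them replace 2-nitrophenyl, giving a 1.8-fold higher number from compound 1 to compound 2 (0.25 log units; within the scatter) and a 1.1-fold higher number from compound 1 to compound 3 (0.05 log units; within the scatter), and both stay within the scatter. Among the measured compounds shown here, no measured step brings in ethoxycarbonyl, so the data hold no direct precedent for this group. The closest guide is 2-methylphenyl in place of 2,4-dichlorophenyl, a 1.6-fold lower number from compound 2 to compound 3 (0.21 log units; within the scatter), so no step beyond the scatter is expected in this assay. The estimated step is a 1.4-fold lower number from compound 2 to compound 4 (0.15 log units; within the scatter). For compound 4 the expected value is 180000 nM, with an estimated range of 85000 nM to 380000 nM.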

Compound 4, half-maximal cytotoxic concentration: 150000 nM
For compound 4 the middle estimate is 1.2-fold (0.08 log units) above the measured one; low and high end bracket the measured number.
By their numbers in this assay, from the lowest: compounds 1, 4, 3 and 2 (each within the scatter of the next).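

In this assay, exchanging chloro (1 heavy atom, no hydrogen-bond acceptors) for ethoxycarbonyl (5 heavy atoms, 2 hydrogen-bond acceptors) gives a 1.7-fold lower number from compound 2 to compound 4 (0.23 log units; within the scatter), so compound 2 and compound 4 cannot be told apart in this test. Among the compounds shown here, all the earlier steps replaced the whole group on the amide-type nitrogen, whereas this one changes a single aromatic carbon, para to a large group and meta to a chloro group, and leaves that chloro group in place. It shows that, at this one carbon and for this one pair, a much bigger group with a double bond outside the ring brings no readable change in the cytotoxicity number, though no measurement at hand offers an explanation for this.

As far as these compounds go, whether this tolerance extends to other kinds of group remains open, as a single exchange cannot show whether an amine or a carboxylic acid on the same carbon would also stay within the scatter. It is equally unclear whether a longer chain on the ester, such as butoxycarbonyl, would leave the number where it is.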